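Methylenedioxy-free chromanone series: amine size at the benzylic position

This account rests on a few compounds, and the source may have more. Where it says the series, first, only, none or still open, it means among the compounds named here.

Measured so far in an assay on isolated protein for inhibition of Amine oxidase [flavin-containing] B (Homo sapiens), read by fluorescence, with a stated time of 30 min; on this read-out higher numbers stand for weaker inhibition and lower numbers for stronger inhibition:
- compound 1 `COc1cc2c(cc1OC)C(=O)/C(=C/c1cccc(O)c1)CO2`: 190 nM
- compound 2 `COc1cc2c(cc1OC)C(=O)/C(=C/c1ccc(CN(C)C)c(O)c1)CO2`: 882 nM

Compound 2 has the highest number of the two, sitting a 4.6-fold higher number from compound 1 to compound 2 (0.67 log units; beyond the scatter) away from compound 1, a modest step beyond the scatter. Compound 3 `CCN(CC)Cc1ccc(/C=C2\COc3cc(OC)c(OC)cc3C2=O)cc1O` carries the change (diethylamino in place of dimethylamino on a saturated chain carbon bound to an aromatic carbon). For the measured compounds named here, no measured step bears directly on the size of the alkyl groups on this nitrogen; the only step at this position, from compound 1 to compound 2, concerns adding the whole (dimethylamino)methyl group and is no guide to swapping methyl for ethyl. Expect for compound 3, therefore, a change in this assay of about a 1.2-fold higher number from compound 2 to compound 3 (0.10 log units; within the scatter), that is, nothing clearly beyond the scatter, with a slight lean toward a higher number because the (dimethylamino)methyl addition gave a 4.6-fold higher number from compound 1 to compound 2 (0.67 log units; beyond the scatter). The estimate for compound 3 is 1100 nM, between 400 nM and 3000 nM.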

Compound 3, half-maximal inhibitory concentration: 2430 nM
Compound 3: middle estimate off by 2.2-fold (0.34 log units), on the low side; the range from low to high includes it.
By their numbers in this assay, from the lowest: compound 1; then compound 2; then compound 3.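

Working notes: in this assay the alkyl groups on this nitrogen count in their own right, since diethylamino in place of dimethylamino gives a 2.8-fold higher number from compound 2 to compound 3 (0.44 log units; beyond the scatter) as a step beyond the scatter. The whole (diethylamino)methyl addition gives a 13-fold higher number from compound 1 to compound 3 (1.11 log units; beyond the scatter) and so costs more than the (dimethylamino)methyl addition at a 4.6-fold higher number from compound 1 to compound 2 (0.67 log units; beyond the scatter) and the number climbs with amine size across these three compounds, none going against that order. No measured information is available to account for this rise.

From the compounds shown here alone, whether the climb continues with dipropylamino on the same saturated chain carbon remains open. Equally open, going by these compounds, is whether amines closed into a ring, such as pyrrolidine or morpholine, would follow the same order as these open-chain amines.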